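Replacing 4-carboxyphenyl with 1H-1,2,3-triazol-1-yl in compound 3

The compounds below may be only part of what the source reports. "The series", "measured", "known", "first", "only" and "open" are said of these compounds alone.

Of the compounds shown here, three with a shared core have been measured in an ADME assay on SH-SY5Y cells (Homo sapiens) for cytotoxicity, read by MTT assay, with a stated time of 48 h; a lower number here means that less compound is needed, a higher number that more compound is needed for the effect. Compound 1 `NC(=O)c1ccccc1-c1ccccc1C(=O)NCCCCCCCn1cc(-c2cccnc2)nn1` gives 289 nM. Compound 2 `O=C(O)c1cccc(-c2ccccc2C(=O)NCCCCCCCn2cc(-c3cccnc3)nn2)c1` gives > 500 nM, which is a limit of the assay and not a number. Compound 3 `O=C(O)c1ccc(-c2ccccc2C(=O)NCCCCCCCn2cc(-c3cccnc3)nn2)cc1` gives 224 nM. It stands level with compound 1 within the scatter, as a 1.3-fold lower number from compound 1 to compound 3 (0.11 log units; within the scatter) shows, and it is separated from compound 2 by an at least 2.2-fold lower number from compound 2 to compound 3 (0.34 log units; beyond the scatter).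

Compound 4 `O=C(NCCCCCCCn1cc(-c2cccnc2)nn1)c1ccccc1-n1ccnn1` carries a new group at this position: 1H-1,2,3-triazol-1-yl in place of 4-carboxyphenyl on an aromatic carbon. Among the compounds with values here, no measured step brings in this group, so the evidence is indirect and comes from exchanges at the same aromatic carbon. Of these, compound 3 gives a 1.3-fold lower number from compound 1 to compound 3 (0.11 log units; within the scatter) and compound 2 gives an at least 1.7-fold higher number from compound 1 to compound 2 (0.23 log units; that floor lies within the scatter). Only the exchange between compound 2 and compound 3 exceeds the scatter, and the group entering compound 4 differs far more from those groups than they differ from one another. A wide range is therefore warranted, and a reading at the limit of > 500 nM in this assay, at which 1 of the 3 values shown sits, remains possible.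

The expected result in this assay is a 1.3-fold higher number from compound 3 to compound 4 (0.10 log units; within the scatter), with a slight upward lean but no change beyond the scatter. The estimated value for compound 4 is 280 nM, with an expected range of 120 nM to 650 nM.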

Compound 4, half-maximal effective concentration: 35.4 nM
For compound 4 the middle estimate is 7.9-fold (0.90 log units) above the measured one; measured number below the stated range.
By their numbers in this assay, from the lowest: compound 4; then compounds 3 and 1 (each within the scatter of the next). At a limit, above all of these: compound 2.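

In this assay, this aromatic carbon, ortho to a large group, proves more sensitive than the exchanges among the earlier aryl groups showed: 1H-1,2,3-triazol-1-yl gives a 6.3-fold lower number from compound 3 to compound 4 (0.80 log units; beyond the scatter) and an 8.2-fold lower number from compound 1 to compound 4 (0.91 log units; beyond the scatter), and compound 4 has the lowest number of the series, with a five-membered aromatic ring with 3 hetero atoms in place of a six-membered aromatic ring of carbon only. Measured from the other carboxylic acid, the change reads an at least 14-fold lower number from compound 2 to compound 4 (1.14 log units; beyond the scatter), a floor and not a measured size. Compound 2 stands at a limit of the assay and not at a number: the limit of > 500 nM in this assay, at which 1 of the 4 values shown sits.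

The compounds shown do not tell whether the lower number follows from the triazole itself or simply from the absence of the larger aryl group, and they give no measured reason for the step. An unsubstituted phenyl, a 1H-pyrazol-1-yl or a 1H-1,2,4-triazol-1-yl group at this aromatic carbon would separate these readings, and a shorter or longer chain would show whether the step holds elsewhere in the series.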